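This account rests on a few compounds, and the source may have more. Where it says the series, first, only, none or still open, it means among the compounds named here.

Measured so far:
compound 1, `COc1ccc2c(=O)c(/C=C/C(=O)NCc3cccc(F)c3)coc2c1`, 10100 nM in a functional assay on Huh-7 cells (Homo sapiens) for inhibition, read by MTT assay, with a stated time of 48 h; on this read-out lower numbers stand for stronger inhibition and higher numbers for weaker inhibition
compound 2, `COc1ccc(CNC(=O)/C=C/c2coc3cc(OC)ccc3c2=O)cc1`, 7570 nM
compound 3, `COc1ccc2c(=O)c(/C=C/C(=O)NCc3ccc(C)cc3)coc2c1`, 14300 nM

Compound 3 gives the largest of the three numbers, yet the steps of a 1.4-fold higher number from compound 1 to compound 3 (0.15 log units; within the scatter) and a 1.9-fold higher number from compound 2 to compound 3 (0.28 log units; within the scatter) both lie within the scatter, so the three compounds cannot be told apart. Compound 4, `COc1ccc2c(=O)c(/C=C/C(=O)Nc3ccccc3OC)coc2c1`, is the change (2-methoxyphenyl in place of 4-methylbenzyl on an amide-type nitrogen). Among the measured compounds shown here, no measured step resembles it: the steps from compound 1 to compound 2 and to compound 3 only swapped one substituted phenyl for another on the same chain, and all stayed within the scatter. A step beyond the scatter is therefore neither supported nor ruled out, and for compound 4 a number near that of compound 3 is expected, as a step of a 1.2-fold lower number from compound 3 to compound 4 (0.08 log units; within the scatter), giving an estimate of 12000 nM with a range from 4000 nM to 40000 nM.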

Compound 4, half-maximal inhibitory concentration: 32300 nM
Beside the measured number, compound 4's estimate is 2.7-fold (0.43 log units) below it; the measured number falls inside the stated range.
By their numbers in this assay, from the lowest: compounds 2, 1 and 3 (each within the scatter of the next); then compound 4.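

In this assay, among the compounds shown here, 2-methoxyphenyl on the amide-type nitrogen gives the first steps beyond the scatter, all modest: a 2.3-fold higher number from compound 3 to compound 4 (0.35 log units; beyond the scatter), a 4.3-fold higher number from compound 2 to compound 4 (0.63 log units; beyond the scatter) and a 3.2-fold higher number from compound 1 to compound 4 (0.50 log units; beyond the scatter). Swapping substituents among the benzyl groups had moved the number only within the scatter, whereas this change, which also removes the saturated chain carbon, weakens inhibition against all three. No evidence here accounts for the shift.

The loss of the chain carbon and the new ring substitution remain inseparable, and 2-methoxybenzyl would test them apart. On these data alone, the effect of a longer chain, such as 2-phenylethyl, also remains open.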